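This account rests on a few compounds, and the source may have more. Where it says the series, first, only, none or still open, it means among the compounds named here.

In a functional assay on a cell-free system (Platelet, plasma, Homo sapiens) for inhibition (a higher number here means a weaker inhibitor, a lower number a stronger inhibitor), compound 1 `Cc1ccc(N(CCN2CCC(OCC(=O)O)CC2)C(=O)c2cccc(F)c2)cc1` gives 160 nM and stands between compound 2 `O=C(O)COC1CCN(CCN(C(=O)c2cccc(F)c2)c2ccc(Cl)cc2)CC1` at 340 nM and compound 3 `COc1cccc(C(=O)N(CCN2CCC(OCC(=O)O)CC2)c2ccc(Cl)cc2)c1` at 74 nM among the three measured compounds. Compound 4 `COc1ccc(OC)c(C(=O)N(CCN2CCC(OCC(=O)O)CC2)c2ccc(C)cc2)c1` differs from compound 1 by 2,5-dimethoxyphenyl in place of 3-fluorophenyl on a carbonyl carbon and so carries 2,5-dimethoxyphenyl in place of 3-fluorophenyl on a carbonyl carbon. The closest evidence is the modest step of a 4.6-fold lower number from compound 2 to compound 3 (0.66 log units; beyond the scatter) for methoxy in place of fluoro on an aromatic carbon. The step of a 2.1-fold higher number from compound 1 to compound 2 (0.33 log units; beyond the scatter) is also modest but concerns chloro in place of methyl, which compound 4 does not change. Among the compounds with values here, no measured compound carries two methoxy groups. A modest move to a lower number is therefore expected, an estimated 2.3-fold lower number from compound 1 to compound 4 (0.36 log units; beyond the scatter) in this assay overall. Compound 4 is estimated at 70 nM with an expected range from 25 nM to 200 nM in this reading.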

Compound 4, half-maximal inhibitory concentration: > 3000 nM
Compound 4: a limit, no number; the forecaster's own chance of this, stated with the estimate: 2%; middle value at least 42-fold (1.63 log units) away from the limit.
By their numbers in this assay, from the lowest: compound 3; then compound 1; then compound 2. At a limit, above all of these: compound 4.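

Within the data shown here, at the carbonyl carbon, 2,5-dimethoxyphenyl in place of 3-fluorophenyl gives an at least 18-fold higher number from compound 1 to compound 4 (1.27 log units; beyond the scatter) in this assay, a large step where the earlier steps were modest. The value of compound 4 is a limit, not a number: the limit of > 3000 nM in this assay, at which 1 of the 4 values shown sits. The lower number seen in a 4.6-fold lower number from compound 2 to compound 3 (0.66 log units; beyond the scatter) for methoxy in place of fluoro therefore does not carry over to 2,5-dimethoxyphenyl. Still open, going by these compounds, is how a single methoxy group on this ring would read on the core of compound 1. Also open, on these data alone, is how a hydroxy or an amino group would read in its place.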